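Varying the sulfonyl substituent of a shared urea core

This account rests on a few compounds, and the source may have more. Where it says the series, first, only, none or still open, it means among the compounds named here.

Compound 1 `CCCn1cc(S(=O)(=O)c2ccc(CNC(=O)N3Cc4ccncc4C3)cc2)cn1` gives 17 nM in an assay on isolated protein for inhibition of Nicotinamide phosphoribosyltransferase (Homo sapiens), read by mass spectrometry, with stated times of 15 min and 30 min; a higher number here means a weaker inhibitor, a lower number a stronger inhibitor.
Compound 2 `O=C(NCc1ccc(S(=O)(=O)C2CCCOC2)cc1)N1Cc2ccncc2C1` gives 44 nM in this assay.
Compound 3 `O=C(NCc1ccc(S(=O)(=O)N2CCC[C@@H](O)C2)cc1)N1Cc2ccncc2C1` gives 28 nM in this assay.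

Compound 3 holds the second highest of the three numbers, and both neighbours sit close: a 1.6-fold higher number from compound 1 to compound 3 (0.22 log units; within the scatter) and a 1.6-fold lower number from compound 2 to compound 3 (0.20 log units; within the scatter). Compound 4 `O=C(NCc1ccc(S(=O)(=O)N2CCC(N3CCCC3)CC2)cc1)N1Cc2ccncc2C1` carries 4-(pyrrolidin-1-yl)piperidin-1-yl in place of 3-hydroxypiperidin-1-yl on a sulfonyl sulfur. The changes that bear on this step are those at the same sulfonyl sulfur, the largest being a 2.6-fold higher number from compound 1 to compound 2 (0.41 log units; beyond the scatter), the others within the scatter. Every group tried there so far has left the number within a modest span, so a change of similar size is expected in this assay, with no firm direction. Compound 4 is therefore estimated at 40 nM, with a range of 14 nM to 120 nM, an expected step of a 1.4-fold higher number from compound 3 to compound 4 (0.15 log units; within the scatter).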

Compound 4, half-maximal inhibitory concentration: 7.4 nM
Estimate against measurement, compound 4: 5.4-fold (0.73 log units) above; measured number below the stated range.
By their numbers in this assay, from the lowest: compound 4; then compounds 1, 3 and 2 (each within the scatter of the next, the first and the last beyond it).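

The same sulfonyl sulfur proves able to carry a larger group with a clear gain: 4-(pyrrolidin-1-yl)piperidin-1-yl shows a 3.8-fold lower number from compound 3 to compound 4 (0.58 log units; beyond the scatter) against 3-hydroxypiperidin-1-yl and a 5.9-fold lower number from compound 2 to compound 4 (0.77 log units; beyond the scatter) against oxan-3-yl. It also shows a 2.3-fold lower number from compound 1 to compound 4 (0.36 log units; beyond the scatter) against 1-propyl-1H-pyrazol-4-yl, so the two-ring group gives the lowest number of the four, beyond the scatter of each of the others. No measurement shown here explains this gain.

On these data alone, whether the pyrrolidine ring itself matters or any second amine would serve stays open. A dimethylamino group or a plain piperidine on that sulfur would separate these.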